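Swapping the ring on the amide nitrogen of compound 1

The compounds below may be only part of what the source reports. "The series", "measured", "known", "first", "only" and "open" are said of these compounds alone.

Compound 1 `Cc1ccc(OCC(=O)N(Cc2cccs2)c2cnn(C)c2)cc1` is an anilide-like amide in which an aromatic ring sits directly on the amide nitrogen. In an assay on HEK293 cells for agonist activity at transient receptor potential cation channel subfamily M member 8 (Homo sapiens), read by fluorescence and calcium flux, with a stated time of 15 min (a higher number here means that more compound is needed for the effect, a lower number that less compound is needed), compound 1 gives 63000 nM, the highest of the three numbers measured here. Compound 2 `CCN(Cc1cccn1C)C(=O)COc1ccc(C)cc1` gives 21300 nM, and compound 3 `CCN(Cc1ccco1)C(=O)COc1ccc(C)cc1` gives 489 nM, so compound 1 needs the most compound of the three for the same effect.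

Compound 4 `Cc1ccc(OCC(=O)N(Cc2cccs2)c2ccon2)cc1` differs from compound 1 in one place: 1,2-oxazol-3-yl in place of 1-methyl-1H-pyrazol-4-yl on an amide-type nitrogen. For the measured compounds named here, the one measured step in this set, a 44-fold lower number from compound 2 to compound 3 (1.64 log units; beyond the scatter), concerns a different place, a saturated chain carbon bound to the amide nitrogen, and exchanges different rings. Going by the values given here, it shows that a small change of a five-membered aromatic ring can move this assay a great deal, but no measured step exchanges the group on the amide nitrogen itself, so the direction for compound 4 is not anchored by data.

Given that compound 1 starts at 63000 nM, the expectation for compound 4 is a modest move, a 1.6-fold lower number from compound 1 to compound 4 (0.20 log units; within the scatter), in the direction of a lower number. The estimated value for compound 4 is 40000 nM, with a range from 8000 nM to 200000 nM.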

Compound 4, half-maximal effective concentration: 2 nM
Compound 4: middle estimate off by 20000-fold (4.30 log units), on the high side; measured number outside the range, below it.
By their numbers in this assay, from the lowest: compound 4; then compound 3; then compound 2; then compound 1.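

The amide nitrogen turns out to be a highly sensitive position in this assay: the exchange of rings there gives a 32000-fold lower number from compound 1 to compound 4 (4.50 log units; beyond the scatter), a far larger step than the one at the saturated chain carbon, a 44-fold lower number from compound 2 to compound 3 (1.64 log units; beyond the scatter). The size of the change in structure gives no hint of this, since 1-methyl-1H-pyrazol-4-yl and 1,2-oxazol-3-yl are both five-membered aromatic rings with the same counts of hetero atoms, hydrogen-bond donors and hydrogen-bond acceptors, and neither carries a net charge. Those counts therefore do not separate the two groups, and what the step does show is that the identity of the ring on this nitrogen can decide whether the assay needs a very high or a very low concentration, while nothing available here explains the difference.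

Still open, from the compounds shown here alone, is how narrow this preference is, for instance whether 1,2-oxazol-5-yl, a phenyl ring or a group carrying an amine on the amide nitrogen would keep the number low. Also open, going by these compounds, is whether 1,2-oxazol-3-yl on the amide nitrogen would work together with furan-2-yl on the saturated chain carbon.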